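The source may hold more compounds than are shown below. What is called first, only, known or untested is meant among the compounds shown, and "the series" means these compounds.

Compound 2 `O=C(Nc1cccc(-c2oc3cc(-c4ccc(F)cc4)ccc3c(=O)c2O)c1)c1cccc(F)c1` gives 15800 nM in a functional assay on GTL 16 cells for antiproliferative activity against GTL 16 cell line (Homo sapiens), read by CCK-8 assay, with a stated time of 72 h (on this read-out lower numbers stand for stronger inhibition and higher numbers for weaker inhibition), the higher of the two numbers recorded, although compound 1 `COc1cccc(C(=O)Nc2cccc(-c3oc4cc(-c5ccc(F)cc5)ccc4c(=O)c3O)c2)c1`, with 12500 nM, sits within the scatter of it: a 1.3-fold higher number from compound 1 to compound 2 (0.10 log units; within the scatter). Compound 3 `O=C(Nc1cccc(-c2oc3cc(-c4ccc(F)cc4)ccc3c(=O)c2O)c1)c1cc(F)cc(F)c1` differs from compound 2 by fluoro in place of hydrogen on an aromatic carbon. Among the compounds with values here, the one measured step that touches this region, from compound 1 to compound 2, stayed within the scatter, so no step beyond the scatter is expected in this assay, and the expected step is a 1.0-fold higher number from compound 2 to compound 3 (0.01 log units; within the scatter). Compound 3 is therefore estimated at 16000 nM, between 7000 nM and 36000 nM.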

Compound 3, half-maximal inhibitory concentration: 7410 nM
Compound 3: middle estimate off by 2.2-fold (0.33 log units), on the high side; the measured number falls inside the stated range.
By their numbers in this assay, from the lowest: compounds 3, 1 and 2 (each within the scatter of the next, the first and the last beyond it).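

A second fluoro on the 3-fluorophenyl ring, giving the 3,5-difluorophenyl amide, produces the first change beyond the scatter among these compounds in this assay, though a modest one: a 2.1-fold lower number from compound 2 to compound 3 (0.33 log units; beyond the scatter). Against the 3-methoxyphenyl amide the result stays within the scatter, a 1.7-fold lower number from compound 1 to compound 3 (0.23 log units; within the scatter), so the 3,5-difluorophenyl and 3-methoxyphenyl groups cannot be told apart here. Nothing available accounts for the step. On these data alone, it remains open whether a chloro group, a trifluoromethyl group, an amine or a carboxylic acid on this ring would shift the number further, and how the unsubstituted phenyl amide compares.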